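A few compounds are considered here, and "the series" means these few. Any claim that something is new, unique, unknown or untested is made for them only; others in the source may bear on it.

Measured so far in a functional assay on PRK cells (Oryctolagus cuniculus) for cytotoxicity; on this read-out lower numbers stand for higher toxicity in this test and higher numbers for lower toxicity in this test:
Compound 1 `CCCCOC(=O)C(O)Cn1cnc2c(N)ncnc21` gives 200 ug/mL.
Compound 2 `CCOC(=O)C(O)Cn1cnc2c(N)ncnc21` gives > 400 ug/mL, which is a limit of the assay and not a number.

Compound 2 thus stands at the upper edge of what this assay reports, namely (the limit of > 400 ug/mL in this assay, at which 1 of the 2 values shown sits). Compound 3 `CCCOC(=O)C(O)Cn1cnc2c(N)ncnc21` differs from compound 2 by methyl in place of hydrogen on a saturated chain carbon, two bonds along the chain from an oxygen next to a carbonyl group. For the measured compounds named here, the only measured step, an at least 2.0-fold higher number from compound 1 to compound 2 (0.30 log units; that floor lies within the scatter), removed a longer piece of the same chain and changed the read-out by no more than the scatter. Adding back a shorter piece in compound 3 is therefore expected to give no step beyond the scatter, a number no higher from compound 2 to compound 3 (the limit leaves the size open). Compound 3 is estimated at 400 ug/mL, with a range from 200 ug/mL to 800 ug/mL.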

Compound 3, minimum cytotoxic concentration: 100 ug/mL
For compound 3 the middle estimate is 4.0-fold (0.60 log units) above the measured one; the whole stated range lies above it.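

Here one added methyl is enough to shift the read-out: in this assay this change gives an at least 4.0-fold lower number from compound 2 to compound 3 (0.60 log units; beyond the scatter), the first step in this series beyond the scatter. Taking away the next methyl further out on the chain gives a 2.0-fold lower number from compound 1 to compound 3 (0.30 log units; within the scatter), so the clear change lies at the position of the methyl in compound 3. The value of compound 2 is a limit of the assay, so the first step gives only a floor: the limit of > 400 ug/mL in this assay, at which 1 of the 3 values shown sits.

As far as these compounds go, whether a longer chain would stay at this level remains open. So does how a carboxylic acid or an amide in place of the ester would read.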